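A Ring Swap on the Carbonyl Carbon of Compound 2

The source may hold more compounds than are shown below. What is called first, only, known or untested is meant among the compounds shown, and "the series" means these compounds.

In a functional assay on MIA PaCa-2 cells (Homo sapiens) for inhibition, read by MTT assay, with a stated time of 7 days (on this read-out lower numbers stand for stronger inhibition and higher numbers for weaker inhibition), compound 1 (`O=C([C@@H]1CCCN(S(=O)(=O)c2ccc(S(=O)(=O)N3CC[C@@H](O)C3)cc2)C1)N1CCC(F)(F)CC1`) gives 210 nM. Compound 2 (`CCN(CC)S(=O)(=O)c1ccc(S(=O)(=O)N2CCC[C@@H](C(=O)N3CCC(OC)CC3)C2)cc1`) gives 140 nM, and these two numbers lie within the usual scatter of each other, so neither compound can be ranked above the other. The two also differ in more than one place, which leaves no measured single change to lean on. Compound 3 (`CCN(CC)S(=O)(=O)c1ccc(S(=O)(=O)N2CCC[C@@H](C(=O)N[C@H]3CC[C@@H](OC)CC3)C2)cc1`) keeps the rest of compound 2 and changes one group: (4-methoxycyclohexyl)amino in place of 4-methoxypiperidin-1-yl on a carbonyl carbon. In words, (4-methoxycyclohexyl)amino stands in place of 4-methoxypiperidin-1-yl on a carbonyl carbon. Among the measured compounds shown here, no measured pair shows what this swap does, so only a cautious expectation is possible. The expected change is a 1.4-fold higher number from compound 2 to compound 3 (0.15 log units; within the scatter), a slight weakening that would not clearly leave the scatter. For compound 3 the estimated value is 200 nM, with an expected range from 50 nM to 800 nM.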

Compound 3, half-maximal inhibitory concentration: 960 nM
For compound 3 the middle estimate is 4.8-fold (0.68 log units) below the measured one; the whole stated range lies below it.
By their numbers in this assay, from the lowest: compounds 2 and 1 (each within the scatter of the next); then compound 3.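

In this assay, the only measured single change among these compounds turns out to be a large one: a 6.9-fold higher number from compound 2 to compound 3 (0.84 log units; beyond the scatter). This shows that inhibition is sensitive to the group on this carbonyl carbon, and that (4-methoxycyclohexyl)amino, with its carbon-only ring and a hydrogen-bond donor absent from 4-methoxypiperidin-1-yl, does not replace that group without a loss. Nothing measured here gives a reason for this loss.

The swap alters the ring and adds the amide hydrogen together, and the compounds shown cannot tell which of the two matters. Going by these compounds, a (4-methoxycyclohexyl)(methyl)amino group, with a methyl in place of the amide hydrogen on the same carbon-only ring, would help separate the two, while the other stereoisomer of the 4-methoxycyclohexyl ring also remains open.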